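Chain hydroxylation of an alpha-ketooxazole amide hydrolase inhibitor

The source may report more compounds than this note shows. Statements on the series, on what has been measured and on what is new or still open speak of the compounds shown alone.

Compound 1 `O=C(CCCCCCc1ccccc1C(=O)O)c1ncc(-c2ccccn2)o1`: > 600 nM
Compound 2 `Nc1cccc(CCCCCCC(=O)c2ncc(-c3ccccn3)o2)c1`: 30 nM

Two compounds share the same core and chain and differ only in the aryl group at the far end. In an assay for inhibition of Fatty-acid amide hydrolase 1 (Rattus norvegicus) (on this read-out higher numbers stand for weaker inhibition and lower numbers for stronger inhibition), compound 1 gives > 600 nM, which is a limit of this assay and not a number. In this assay compound 2 gives 30 nM, and it is the only number shown. The value of compound 1 is a limit (the limit of > 600 nM in this assay, at which 1 of the 2 values shown sits). The step of an at least 20-fold lower number from compound 1 to compound 2 (1.30 log units; beyond the scatter) shows that the substituent on the terminal ring alone decides whether a number is reached at all.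

Compound 3 `O=C(CCCCCC(O)c1ccccc1)c1ncc(-c2ccccn2)o1` is not yet measured. It differs from compound 2 by hydroxy(phenyl)methyl in place of 3-aminobenzyl on a saturated chain carbon, five bonds along the chain from a carbonyl carbon. For the measured compounds named here, the measured step bears on it only loosely: it shows the terminal aryl region to be sensitive, but no measured pair tells what a hydroxyl on the chain does, nor what the loss of the aniline costs. Given the size of an at least 20-fold lower number from compound 1 to compound 2 (1.30 log units; beyond the scatter), a step weakening in this assay is expected, estimated as a 5.0-fold higher number from compound 2 to compound 3 (0.70 log units; beyond the scatter). For compound 3 the estimate is 150 nM, within 40 nM to 600 nM.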

Compound 3, inhibition constant: 35 nM
Compound 3: middle estimate off by 4.3-fold (0.63 log units), on the high side; the whole stated range lies above it.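

In this assay, hydroxy(phenyl)methyl in place of 3-aminobenzyl gives a 1.2-fold higher number from compound 2 to compound 3 (0.07 log units; within the scatter), so this exchange does not separate the two compounds on this read-out. For the compounds shown here, the earlier pair showed only that the group at the far end of the chain can decide whether a number is reached at all, whereas this pair shows that a number of this size does not depend on an amine on the terminal ring, provided that a hydroxyl stands on the chain carbon five bonds along the chain from a carbonyl carbon. Nothing shown here accounts for why the two groups cannot be told apart on this read-out.

On these data alone, the exchange removes the amine and adds the hydroxyl in a single step, so what each change contributes alone stays open, and a plain phenyl on the same saturated chain without the hydroxyl would be needed to divide the two. Also open, as far as these compounds go, is how much the hydroxyl itself matters, which a methyl ether or a ketone at that chain carbon, or a longer chain carrying the same hydroxyl, would address.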